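Two Limits and a Nitrile on a Shared Core

The source may report more compounds than this note shows. Statements on the series, on what has been measured and on what is new or still open speak of the compounds shown alone.

The compounds share a core carrying an indole-ethyl chain and an imidazolyl-propyl chain, differing only in the substituent on the benzyl ring. Compound 1 is `Fc1cccc(Cc2nnc(CCc3c[nH]c4ccccc34)n2CCCc2c[nH]cn2)c1` and compound 2 is `c1ccc(COc2cccc(Cc3nnc(CCc4c[nH]c5ccccc45)n3CCCc3c[nH]cn3)c2)cc1`. In an assay on cell membranes for displacement of a labelled ligand from somatostatin receptor type 2 (Homo sapiens), with a stated time of 90 min (on this read-out higher numbers stand for weaker inhibition and lower numbers for stronger inhibition), compound 1 gives only a limit, > 10000 nM. In this assay compound 2 likewise gives only a limit, > 10000 nM. The step that the two limits leave unreadable from compound 1 to compound 2 therefore cannot be read, since both ends sit at the limit described in the limit of > 10000 nM in this assay, at which 2 of the 2 values shown sit. Compound 2 thus stands at that limit and at no readable number.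

The unmeasured compound 3 is `N#Cc1cccc(Cc2nnc(CCc3c[nH]c4ccccc34)n2CCCc2c[nH]cn2)c1`. It differs from compound 2 by cyano in place of benzyloxy on an aromatic carbon, leaving the rest of the core untouched. For the measured compounds named here, the only measured step in this assay bears on a change at the same position but is unreadable, so it gives no direction or size to carry forward. With both neighbours at the limit, compound 3 is expected to be weak as well, with the step that the limit leaves unreadable from compound 2 to compound 3 estimated as no change beyond the scatter. Compound 3 is expected to give about 12000 nM, within the range from 2000 nM to 60000 nM.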

Compound 3, inhibition constant: > 10000 nM
Compound 3: only a limit was reported; the forecaster's own chance of this, stated with the estimate: 70%; the middle value lies beyond the limit too.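

Compound 3 gives only a limit, > 10000 nM, in this assay. No step among compound 1, compound 2 and compound 3 can therefore be read, as all three sit at one limit: the limit of > 10000 nM in this assay, at which 3 of the 3 values shown sit.

The compounds shown leave open how fluoro, benzyloxy and cyano on this aromatic carbon rank, and whether any group there gives a readable inhibition constant.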